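Ester in place of the aminoalkyl amide on the carbonyl

This account rests on a few compounds, and the source may have more. Where it says the series, first, only, none or still open, it means among the compounds named here.

Compound 3 `CCn1c(C(=O)NCCCN(C)C)ccc1C(CC)(CC)c1ccc(OCC(O)C(C)(C)C)c(C)c1` stands second highest of the three numbers in a functional assay on PC-3 cells (Homo sapiens), read by MTT assay, with a stated time of 48 h (a lower number here means a stronger inhibitor, a higher number a weaker inhibitor), where compound 3 gives 3100 nM. Compound 2 `CCn1c(C(=O)NCCN(C)C)ccc1C(CC)(CC)c1ccc(OCC(O)C(C)(C)C)c(C)c1` gives 1630 nM and compound 1 `CCOC(=O)CN(C)C(=O)c1ccc(C(CC)(CC)c2ccc(OCC(O)C(C)(C)C)c(C)c2)n1CC` gives 25500 nM; a 1.9-fold higher number from compound 2 to compound 3 (0.28 log units; within the scatter). Compound 4 `CCn1c(C(=O)OCc2ccc(F)cc2)ccc1C(CC)(CC)c1ccc(OCC(O)C(C)(C)C)c(C)c1` differs from compound 3 by (4-fluorobenzyl)oxy in place of (3-(dimethylamino)propyl)amino on a carbonyl carbon. For the measured compounds named here, the steps that bear on this are a 16-fold lower number from compound 1 to compound 2 (1.19 log units; beyond the scatter) and an 8.2-fold lower number from compound 1 to compound 3 (0.92 log units; beyond the scatter), both of which bring in a dimethylamino-bearing chain and lower the number clearly. Compound 4 carries no dimethylamino group, so a rise is expected because compound 1 without one gives 25500 nM. The expected step is a 5.8-fold higher number from compound 3 to compound 4 (0.76 log units; beyond the scatter). Compound 4 is therefore estimated at 18000 nM, with a range from 5000 nM to 60000 nM.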

Compound 4, half-maximal inhibitory concentration: > 50000 nM
Compound 4 was reported as a limit (the forecaster's own chance of this, stated with the estimate: 10%); at least 2.7-fold (0.44 log units) between middle value and limit.
By their numbers in this assay, from the lowest: compounds 2 and 3 (each within the scatter of the next); then compound 1. At a limit, above all of these: compound 4.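

In this assay, compound 4 is reported only as a limit: the limit of > 50000 nM in this assay, at which 1 of the 4 values shown sits. Putting (4-fluorobenzyl)oxy on this carbonyl carbon gives an at least 16-fold higher number from compound 3 to compound 4 (1.20 log units; beyond the scatter) and an at least 30-fold higher number from compound 2 to compound 4 (1.48 log units; beyond the scatter), so an ester bearing an aromatic ring does not keep the level of either dimethylamino amide. Putting it in place of ((ethoxycarbonyl)methyl)(methyl)amino gives an at least 1.9-fold higher number from compound 1 to compound 4 (0.29 log units; that floor lies within the scatter), so this step shows no clear change.

The change removes the dimethylamino group and the amide hydrogen together, leaving open which of them matters. A (3-(dimethylamino)propyl)oxy ester or a (4-fluorobenzyl)amino amide on this carbonyl carbon would separate the two.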